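Swapping 4-chlorophenyl for 4-methoxyphenyl on the shared core

This account rests on a few compounds, and the source may have more. Where it says the series, first, only, none or still open, it means among the compounds named here.

In a functional assay on MCF7 cells (Homo sapiens) for inhibition, read by MTT assay, with a stated time of 5 days (a higher number here means a weaker inhibitor, a lower number a stronger inhibitor), compound 1 `Cc1cc(Nc2nc(NCc3cccc(Cl)c3)nc3[nH]ncc23)n[nH]1` gives 5620 nM, compound 2 `Cc1cc(Nc2nc(NCc3ccc(Cl)cc3)nc3[nH]ncc23)n[nH]1` gives 860 nM and compound 3 `Cc1cc(Nc2nc(NCc3ccc(F)cc3F)nc3[nH]ncc23)n[nH]1` gives 670 nM. Compound 2 sits at the lower end of these three numbers: the gap to its nearest neighbour is a 1.3-fold lower number from compound 2 to compound 3 (0.11 log units; within the scatter), and the gap to the furthest is a 6.5-fold lower number from compound 1 to compound 2 (0.82 log units; beyond the scatter).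

Compound 4 `COc1ccc(CNc2nc(Nc3cc(C)[nH]n3)c3cn[nH]c3n2)cc1` differs from compound 2 in a single place: methoxy in place of chloro on an aromatic carbon. This puts methoxy in place of chloro on an aromatic carbon, para to a large group. Among the compounds with values here, no measured compound carries methoxy, so the evidence is indirect. Changes on this phenyl ring have produced an 8.4-fold lower number from compound 1 to compound 3 (0.92 log units; beyond the scatter), but also a 1.3-fold lower number from compound 2 to compound 3 (0.11 log units; within the scatter). The two compounds with a substituent in the position that methoxy would occupy, compound 2 and compound 3, are the ones that stay close together, so only a small change is expected, and its direction is uncertain. The expected step is a 1.4-fold higher number from compound 2 to compound 4 (0.14 log units; within the scatter). For compound 4 the estimated value is 1200 nM, with an expected range of 400 nM to 3600 nM.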

Compound 4, half-maximal inhibitory concentration: 3320 nM
For compound 4 the middle estimate is 2.8-fold (0.44 log units) below the measured one; the measured number falls inside the stated range.
By their numbers in this assay, from the lowest: compounds 3 and 2 (each within the scatter of the next); then compounds 4 and 1 (each within the scatter of the next).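

In this assay, methoxy in place of chloro on this aromatic carbon is a real change (a 3.9-fold higher number from compound 2 to compound 4 (0.59 log units; beyond the scatter)), and the number also stands well clear of that of the 2,4-difluorophenyl compound (a 5.0-fold higher number from compound 3 to compound 4 (0.70 log units; beyond the scatter)). A substituent at this place therefore does not by itself keep the number close to those of compound 2 and compound 3, and compound 4 goes against that reading. The 4-methoxyphenyl compound instead stays level with the 3-chlorophenyl compound (a 1.7-fold lower number from compound 1 to compound 4 (0.23 log units; within the scatter)). Nothing measured here explains why chloro and methoxy part in this way. From the compounds shown here alone, it remains open whether a hydroxyl, an ethoxy or a dimethylamino group at the same place would follow chloro or methoxy.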